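A Third Chloro Group on Compound 3

The source may report more compounds than this note shows. Statements on the series, on what has been measured and on what is new or still open speak of the compounds shown alone.

Measured in a functional assay on BEAS-2B cells (Homo sapiens) for inhibition, read by MTT assay, with a stated time of 72 h; a lower number here means a stronger inhibitor, a higher number a weaker inhibitor:

Compound 1 `C=C(c1cc(Cl)cc(Cl)c1OCc1ccccc1)C1COC2(CCCCC2)OO1`: > 100000 nM (a limit)
Compound 2 `C=C(c1cc(Cl)cc(Cl)c1OCc1ccccc1)C1COC2(CCCC2)OO1`: 28600 nM
Compound 3 `C=C(c1ccc(Cl)c(Cl)c1)C1COC(C)(C)OO1`: > 100000 nM (a limit)

Compound 3 is known only through a limit, > 100000 nM, and no number exists for it. That places it at the limit of > 100000 nM in this assay, at which 2 of the 3 values shown sit. Compound 4 `C=C(c1ccc(Cl)c(Cl)c1Cl)C1COC(C)(C)OO1` differs from compound 3 by one change: chloro in place of hydrogen on an aromatic carbon, with chloro in place of hydrogen on an aromatic carbon. Among the measured compounds shown here, no measured step gives the size of this change in this assay, so only a small move toward stronger inhibition is expected. The expected size is an at least 1.4-fold lower number from compound 3 to compound 4 (0.15 log units; that floor lies within the scatter). Compound 4 is estimated at 70000 nM, with an expected range from 25000 nM to 200000 nM.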

Compound 4, half-maximal inhibitory concentration: 10200 nM
Compound 4: the middle estimate sits 6.9-fold (0.84 log units) above what was measured; the measured number lies below the stated range.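

In this assay chloro in place of hydrogen on the aromatic carbon, ortho to a chloro group and ortho to a large group, gives an at least 9.8-fold lower number from compound 3 to compound 4 (0.99 log units; beyond the scatter) and so supplies the first measured size for a single change in this set. Going by these compounds, that step is only a floor, and its full size stays unknown, because compound 3 is a limit and not a number: the limit of > 100000 nM in this assay, at which 2 of the 4 values shown sit.

On these data alone, whether bromo, methyl or methoxy at this position would give a similar step remains open, as does whether the chloro step carries over to the core of compound 2.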